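The source may hold more compounds than are shown below. What is called first, only, known or untested is meant among the compounds shown, and "the series" means these compounds.

Compound 1 `Cc1cccc2cc(-c3ccc(Br)cc3)oc12`: 46.8%
Compound 2 `Cc1cccc2cc(-c3ccccc3Br)oc12`: 44.8%

In an assay on cells for inhibition of Amine oxidase [flavin-containing] A (Homo sapiens), read by fluorescence and Amplex Red, with a stated time of 15 min, tested at 100 uM (a higher number here means more inhibition at the concentration tested (going by the name of the read-out), a lower number less inhibition), compound 1 gives 46.8% and compound 2 gives 44.8%. Compound 2 thus carries the smaller of the two numbers, but its nearest neighbour, compound 1, stands only slightly higher, and the two values lie within the scatter of each other, so no order between them can be read from these data. The step under consideration leads from compound 2 to compound 3 `Cc1cccc2cc(-c3ccccc3)oc12`, which has not yet been measured in this assay. The change is hydrogen in place of bromo on an aromatic carbon. Among the measured compounds shown here, no comparable step between measured compounds is available, so the size of such a change in this assay is not known from these two results. The expectation is that compound 3 will show somewhat less inhibition than its parent, with an estimated step of a number 8.8 percentage points lower from compound 2 to compound 3 (within the scatter), possibly reaching beyond the scatter, though the uncertainty is wide. Compound 3 is therefore estimated at 36% in this assay, with a range from 15% to 55%.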

Compound 3, a percentage reported as inhibition, at one concentration (the size of the read-out at that concentration, not a potency): 53.9%
Beside the measured number, compound 3's estimate is 17.9 percentage points below it; the range from low to high includes it.
By their numbers in this assay, from the lowest: compounds 2, 1 and 3 (each within the scatter of the next).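

In this assay, hydrogen in place of bromo on an aromatic carbon ortho to a large group gives a number 9.1 percentage points higher from compound 2 to compound 3 (within the scatter), and the same exchange starting from compound 1 gives a number 7.1 percentage points higher from compound 1 to compound 3 (within the scatter). Until now the contribution of the bromo could not be judged, since both measured compounds carried it; the two steps now show that its removal leaves the inhibition at the tested concentration within the scatter. The bromo is therefore not required for the level of inhibition seen in this small set, and neither step can be read as a real gain from losing it.

Nothing available on these compounds bears on the reason for this result. It remains open whether another group on this aromatic carbon, such as an amine, a methoxy group or a carboxylic acid, would move the inhibition beyond the scatter, and since all three readings come from a single concentration, they leave the potency of these compounds undefined.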